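Working notes on the step from compound 3 to compound 4

The source may report more compounds than this note shows. Statements on the series, on what has been measured and on what is new or still open speak of the compounds shown alone.

Measured in an ADME assay on HaCaT cells (Homo sapiens) for inhibition, read by sulforhodamine B assay, with a stated time of 48 h; on this read-out lower numbers stand for stronger inhibition of growth and higher numbers for weaker inhibition of growth:
- compound 1 `CCOC(=O)c1nn(-c2ccccc2)c(-c2ccc(C)cc2)c1CNC(C)(C)C`: 72100 nM; > 585000 nM (2 entries)
- compound 2 `CC(C)(C)NCc1c(C(=O)O)nn(-c2ccccc2)c1-c1ccc(F)cc1`: > 680000 nM
- compound 3 `CC(C)(C)NCc1c(C(=O)O)nn(-c2ccccc2)c1-c1ccccc1`: > 716000 nM

Compound 3 stands only at a limit, > 716000 nM, so it offers no number to start from. Compound 2 likewise gives only a limit, > 680000 nM. For the measured compounds named here, compound 1 holds the only number in the set, and it stands alongside limits: the several entries of compound 1 in this assay, 72100 nM; > 585000 nM (2 entries).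

Compound 4 `Cc1ccc(-c2c(CNC(C)(C)C)c(C(=O)O)nn2-c2ccccc2)cc1` carries methyl in place of hydrogen on an aromatic carbon, para to a large group, so that phenyl becomes 4-methylphenyl: methyl in place of hydrogen on an aromatic carbon. Going by the values given here, compound 1 also carries 4-methylphenyl, but no measured step isolates that group.

Among the compounds with values here, the one measured step that bears on this change is also a swap on an aromatic carbon: a step that the two limits leave unreadable from compound 2 to compound 3. It has no readable size and gives no direction. Within the data shown here, with compound 3 at > 716000 nM and no measured step of readable size, no shift beyond the scatter is expected. The estimated step, an at least 1.0-fold lower number from compound 3 to compound 4 (0.01 log units; that floor lies within the scatter), is expected to have no meaningful direction. For compound 4 the expected value is 690000 nM, with an estimated range of 250000 nM to 900000 nM, and the report is expected to be a limit rather than a number.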

Compound 4, concentration for 50% growth inhibition: > 688000 nM
Compound 4 gave a limit, no number; the forecaster's own chance of this, stated with the estimate: 85%; the middle value is on the limit's open side.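

In this assay compound 4 gives only a limit, > 688000 nM. For the compounds shown here, compound 2 and compound 3 also stand at limits, so no step from either to compound 4 can be read. The compounds shown leave open whether methyl in place of hydrogen on an aromatic carbon changes growth inhibition at all.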